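This account rests on a few compounds, and the source may have more. Where it says the series, first, only, none or still open, it means among the compounds named here.

Measured in a functional assay on ACHN cells (Homo sapiens) for antiproliferative activity, read by sulforhodamine B assay; a lower number here means a stronger inhibitor of growth, a higher number a weaker inhibitor of growth:
- compound 1 `CC(C)CCCOc1cccc(O)c1C(=O)/C=C/c1ccc(O)cc1`: 3630 nM
- compound 2 `CC(C)(C)CCOc1cccc(O)c1C(=O)/C=C/c1ccc(O)cc1`: 3140 nM
- compound 3 `O=C(/C=C/c1ccc(O)cc1)c1c(O)cccc1OCCC1CCCCC1`: > 30000 nM, a limit of the assay

Compound 3 has only a limit and no number, and it stands at the limit of > 30000 nM in this assay, at which 1 of the 3 values shown sits. Compound 4 `CCCCOc1cccc(O)c1C(=O)/C=C/c1ccc(O)cc1` differs from compound 3 by ethyl in place of cyclohexyl on a saturated chain carbon, two bonds along the chain from an oxygen on an aromatic ring. This is ethyl in place of cyclohexyl on a saturated chain carbon, two bonds along the chain from an oxygen on an aromatic ring, so 2-cyclohexylethoxy gives way to butoxy.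

Two measured steps end at cyclohexyl at this same place: an at least 8.2-fold higher number from compound 1 to compound 3 (0.91 log units; beyond the scatter), and an at least 9.5-fold higher number from compound 2 to compound 3 (0.98 log units; beyond the scatter). The third step, between the two chains without a ring, is a 1.2-fold lower number from compound 1 to compound 2 (0.06 log units; within the scatter). Within the data shown here, no measured compound carries the unbranched butyl chain, so the effect of that shorter chain remains open.

Compound 1 gives 3630 nM and compound 2 gives 3140 nM, so losing the ring is expected to bring compound 4 back towards their level. In this assay this means an expected move to a lower number, of roughly the size of those two steps. The step expected is an at least 5.0-fold lower number from compound 3 to compound 4 (0.69 log units; beyond the scatter). For compound 4 the estimate is 6000 nM, with an expected range from 2000 nM to 20000 nM.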

Compound 4, concentration for 50% growth inhibition: > 30000 nM
Compound 4: no number, only a limit; the forecaster's own chance of this, stated with the estimate: 10%; middle value at least 5.0-fold (0.69 log units) from the limit.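

In this assay compound 4 gives only a limit, and the step from compound 3 to compound 4 cannot be read, as both values are limits: the limit of > 30000 nM in this assay, at which 2 of the 4 values shown sit.

The unbranched butoxy chain stands apart from both chains with a branched end, with an at least 9.5-fold higher number from compound 2 to compound 4 (0.98 log units; beyond the scatter) and with an at least 8.2-fold higher number from compound 1 to compound 4 (0.91 log units; beyond the scatter), so the earlier drop at compound 3 can no longer be tied to the cyclohexyl ring alone. Among these four compounds, only the chains ending in the isobutyl of compound 1 and the tert-butyl of compound 2 give a number, and the cyclohexyl of compound 3 goes against any reading that a bulky chain end is enough.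

From the compounds shown here alone, how far compound 3 and compound 4 lie beyond their limits stays unknown, so the two cannot be placed in order. Going by these compounds, whether a longer unbranched chain such as hexyloxy, or an amine or a carboxylic acid at the end of the chain, would give a number in this assay also stays open.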